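From Methoxy to Chloro: An Unmeasured Step

This account rests on a few compounds, and the source may have more. Where it says the series, first, only, none or still open, it means among the compounds named here.

Compound 1 `Cc1c(COc2cccc(OCC3CCOCC3)c2)[nH]c2ccc(C(=O)O)cc2c1=O`: < 50 mL/min/kg
Compound 2 `Cc1ccc2[nH]c(COc3cccc(OCC4CCOCC4)c3)c(C)c(=O)c2c1`: "not determined" (no result reported)
Compound 3 `COc1ccc2[nH]c(COc3cccc(OCC4CCOCC4)c3)c(C)c(=O)c2c1`: "not determined" (no result reported)

In an in vitro ADME assay on microsomes from liver (Mus musculus) for metabolic stability, tested at 0.2 uM (a lower number here means slower removal, a higher number faster removal of the compound), compound 3 has no single number, its entry reading "not determined" (no result reported). Compound 2 is in the same position, with "not determined" (no result reported). Compound 1 gives < 50 mL/min/kg, which is a limit and not a number. Within the data shown here, this leaves the limit of < 50 mL/min/kg in this assay, at which 1 of the 3 values shown sits, as the only evidence on the scale.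

The next structure is compound 4 `Cc1c(COc2cccc(OCC3CCOCC3)c2)[nH]c2ccc(Cl)cc2c1=O`. The step chloro in place of methoxy on an aromatic carbon puts chloro in place of methoxy on an aromatic carbon. Among the measured compounds shown here, no measured step shows the effect of this swap, so no shift beyond the scatter is expected in this assay. Compound 4 is expected at about 120 mL/min/kg, within an estimated range of 50 mL/min/kg to 300 mL/min/kg.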

Compound 4, clearance: > 1000 mL/min/kg
Compound 4: no number, only a limit; the forecaster's own chance of this, stated with the estimate: 30%; middle value at least 8.3-fold (0.92 log units) from the limit.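

This position now has one readable step: in this assay, exchanging the carboxy group for chloro gives an at least 20-fold higher number from compound 1 to compound 4 (1.30 log units; beyond the scatter). Compound 4 gives > 1000 mL/min/kg, which is a limit of the assay and not a number. Steps from compound 2 and from compound 3 cannot be read, as neither compound has a value.

The limits leave the full size of the step open. Also open, going by these compounds, is whether a nitrile or an amide on this aromatic carbon would fall closer to compound 1 or to compound 4.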